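A few compounds are considered here, and "the series" means these few. Any claim that something is new, unique, unknown or untested is made for them only; others in the source may bear on it.

Measured in a physicochemical assay for solubility, in phosphate buffer; on this read-out lower numbers stand for lower solubility and higher numbers for higher solubility:

- compound 1 `CC(C)C(NC(=O)Cn1ccc2c(=O)n(Cc3ccccc3)c(=O)[nH]c2c1=O)C(=O)C(F)(F)F` gives 730 ug/mL
- compound 2 `CC(C)C(NC(=O)Cn1c(-c2ccccc2)cc2c(=O)n(CC(N)=O)c(=O)[nH]c2c1=O)C(=O)C(F)(F)F` gives 130 ug/mL
- compound 3 `CC(C)C(NC(=O)Cn1ccc2c(O)nc(O)nc2c1=O)C(=O)C(F)(F)F` gives > 5000 ug/mL, which is a limit and not a number

Among the compounds with values here, only two of these readings are true numbers, and compound 2 holds the lower one. At 130 ug/mL compound 2 sits under compound 1 at 730 ug/mL, a gap beyond the usual scatter.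

Compound 4 `COc1ccc(Cn2c(=O)[nH]c3c(=O)n(CC(=O)NC(C(=O)C(F)(F)F)C(C)C)c(-c4ccccc4)cc3c2=O)cc1` has not yet been measured in this assay. It differs from compound 2 in one place: 4-methoxyphenyl in place of carbamoyl on a saturated chain carbon bound to an aromatic nitrogen. In short, 4-methoxyphenyl stands in place of carbamoyl on a saturated chain carbon bound to an aromatic nitrogen, which turns carbamoylmethyl into 4-methoxybenzyl.

Within the data shown here, no two measured compounds differ in one place only, so the data offer no direct guide to this change. The expectation is therefore a judgement: a clear fall in this assay, beyond the scatter, from the 130 ug/mL of compound 2. The estimated change is a 5.2-fold lower number from compound 2 to compound 4 (0.72 log units; beyond the scatter). Compound 4 is expected at 25 ug/mL, within a range of 6 ug/mL to 80 ug/mL.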

Compound 4, solubility: 230 ug/mL
For compound 4 the middle estimate is 9.2-fold (0.96 log units) below the measured one, outside the stated range (above it).
By their numbers in this assay, from the lowest: compounds 2 and 4 (each within the scatter of the next); then compound 1. At a limit, above all of these: compound 3.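

In this assay, the place on a saturated chain carbon bound to an aromatic nitrogen now has its first direct comparison: turning carbamoylmethyl into 4-methoxybenzyl gives a 1.8-fold higher number from compound 2 to compound 4 (0.25 log units; within the scatter). Within the data shown here, although a carbamoyl group leaves and a six-membered aromatic ring of carbon only enters, this pair shows no change beyond the usual scatter, something the earlier compounds could not show because no two of them differed in one place only. No measurement shown offers an explanation for this result.

On these data alone, whether other groups at this place would behave the same remains open, for example an amine, a carboxylic acid or a longer chain. This is also a single pair, so it cannot tell whether the same exchange would give a similar result on the core of compound 1.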